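The source may report more compounds than this note shows. Statements on the series, on what has been measured and on what is new or still open speak of the compounds shown alone.

Measured compounds:
- compound 1 `CC1CCCC(C(=O)N2CC(c3nc(-c4cccc(Cl)c4)no3)C2)C1`: 410 nM
- compound 2 `O=C(c1cccc(F)c1)N1CC(c2nc(-c3cccc(Cl)c3)no2)C1`: a limit, > 10000 nM
- compound 3 `O=C(C1CCC(F)(F)CC1)N1CC(c2nc(-c3cccc(Cl)c3)no2)C1`: 180 nM

All three share one core and differ only in the group attached to the carbonyl carbon. In an assay on HEK293 cells for positive allosteric modulation of metabotropic glutamate receptor 5 (Homo sapiens), read by FLIPR (a higher number here means that more compound is needed for the effect, a lower number that less compound is needed), compound 3 gives 180 nM, the lowest of the two numbers shown. Its nearest neighbour is compound 1, and the shift is a 2.3-fold lower number from compound 1 to compound 3 (0.36 log units; beyond the scatter). Compound 2 reaches only a limit of this assay, (the limit of > 10000 nM in this assay, at which 1 of the 3 values shown sits). The corresponding change, an at least 55-fold lower number from compound 2 to compound 3 (1.74 log units; beyond the scatter), shows that the move from a flat aromatic group to a saturated six-membered ring on the carbonyl carbon mattered greatly here.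

Compound 4 `COC1CCN(C(=O)N2CC(c3nc(-c4cccc(Cl)c4)no3)C2)CC1` has not yet been measured. The change from compound 3 is 4-methoxypiperidin-1-yl in place of 4,4-difluorocyclohexyl on a carbonyl carbon. The ring stays six-membered and non-aromatic. The closer comparison is a 2.3-fold lower number from compound 1 to compound 3 (0.36 log units; beyond the scatter), a modest shift between two such rings, rather than an at least 55-fold lower number from compound 2 to compound 3 (1.74 log units; beyond the scatter). A modest step is therefore expected, and with the carbonyl carbon now bearing a nitrogen-containing ring the direction is uncertain; the estimate leans toward a somewhat higher number, a 2.5-fold higher number from compound 3 to compound 4 (0.40 log units; beyond the scatter). For compound 4 the expected value in this assay is 450 nM, with a range from 120 nM to 1800 nM.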

Compound 4, half-maximal effective concentration: > 10000 nM
Compound 4 was reported as a limit; the forecaster's own chance of this, stated with the estimate: 10%; middle value at least 22-fold (1.34 log units) from the limit.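

Compound 4 reaches only a limit in this assay: the limit of > 10000 nM in this assay, at which 2 of the 4 values shown sit. A six-membered non-aromatic ring on the carbonyl carbon therefore does not by itself keep the effect: 4-methoxypiperidin-1-yl in place of 4,4-difluorocyclohexyl gives an at least 55-fold higher number from compound 3 to compound 4 (1.74 log units; beyond the scatter), and in place of 3-methylcyclohexyl it gives an at least 24-fold higher number from compound 1 to compound 4 (1.38 log units; beyond the scatter). The link between a saturated ring and a low number holds here only for the carbon-only rings of compound 1 and compound 3, and compound 4 goes against it.

Compound 4 brings in a ring nitrogen and a methoxy group together, and the compounds shown do not separate the two, as a plain piperidin-1-yl or a 4-methoxycyclohexyl group could. From the compounds shown here alone, the step between compound 2 and compound 4 cannot be read, as both values are limits, so how those two groups compare also stays open.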